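The compounds below may be only part of what the source reports. "The series", "measured", "known", "first", "only" and "open" are said of these compounds alone.

Compound 1 `CS(=O)(=O)Nc1ccc2c(c1)S(=O)(=O)N=C(c1c(O)c(-c3cccs3)nn(CC3CCC3)c1=O)N2`, compound 2 `COC(C)(C)CCn1nc(-c2cccs2)c(O)c(C2=NS(=O)(=O)c3cc(NS(C)(=O)=O)ccc3N2)c1=O` and compound 3 `CCC(C)n1nc(-c2cccs2)c(O)c(C2=NS(=O)(=O)c3cc(NS(C)(=O)=O)ccc3N2)c1=O` share one core and differ in the chain on an aromatic nitrogen. All three have been measured in an in vitro ADME assay on microsomes from liver (Homo sapiens) for metabolic stability, tested at 5 uM; a higher number here means that the compound lasts longer, a lower number that the compound disappears faster. Compound 1 gives > 1 h, which is a limit and not a number. Compound 2 gives > 1 h, again a limit. Compound 3 gives > 1 h, also a limit, so it has no exact half-life to start from. The series as a whole stands at the limit of > 1 h in this assay, at which 3 of the 3 values shown sit.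

Compound 4 `CS(=O)(=O)Nc1ccc2c(c1)S(=O)(=O)N=C(c1c(O)c(-c3cccs3)nn(CCC3CCC3)c1=O)N2` follows from compound 3 by one change: 2-cyclobutylethyl in place of sec-butyl on an aromatic nitrogen. In words, 2-cyclobutylethyl takes the place of sec-butyl on an aromatic nitrogen. Three measured steps exchange the chain at this same place: a step that the two limits leave unreadable from compound 1 to compound 3, a step that the two limits leave unreadable from compound 2 to compound 3 and a step that the two limits leave unreadable from compound 1 to compound 2. None of them gives a size or a direction. The first of these counts most, as compound 1 carries cyclobutylmethyl, the chain closest to the entering group.

No change beyond the scatter is therefore expected in this assay, and no direction is favoured. The estimated step is a step that the limit leaves unreadable from compound 3 to compound 4. For compound 4 the expected half-life is 1.5 h, with an estimated range from 0.8 h to 4 h.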

Compound 4, half-life: > 1 h
Compound 4: a limit, no number; the forecaster's own chance of this, stated with the estimate: 70%; the middle value does not contradict the limit.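

In this assay compound 4 gives > 1 h, which is a limit and not a number, so its steps to compound 1, compound 2 and compound 3 cannot be read. The series stands as follows: the limit of > 1 h in this assay, at which 4 of the 4 values shown sit. The compounds shown leave open how long each half-life actually is and whether the chain on the aromatic nitrogen alters it at all.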